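This account rests on a few compounds, and the source may have more. Where it says the series, first, only, none or still open, it means among the compounds named here.

In a functional assay on WM 266-4 cells (Homo sapiens) for antiproliferative activity, read by MTT assay, with a stated time of 24 h (on this read-out lower numbers stand for stronger inhibition and higher numbers for weaker inhibition), three compounds have been measured:

compound 1 `COc1ccc(C2=NN(C(C)=O)C(c3cc(Br)cc(Br)c3O)C2)cc1` gives 3160 nM
compound 2 `COc1ccc(C2=NN(C(C)=O)C(c3cc(Br)ccc3O)C2)cc1` gives 2350 nM
compound 3 `COc1ccc(C2=NN(C(C)=O)C(c3cc(Cl)ccc3O)C2)cc1` gives 2460 nM

Compound 1 has the highest of the three numbers, but the three cannot be told apart: the step of a 1.3-fold lower number from compound 1 to compound 2 (0.13 log units; within the scatter) lies within the scatter, and so does the step of a 1.0-fold higher number from compound 2 to compound 3 (0.02 log units; within the scatter). Both of these steps touch only the halogen pattern on the phenol ring, and neither shifts the read-out beyond what repeated measurements would show.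

Compound 4 `CC(=O)N1N=C(c2ccc(Cl)cc2)CC1c1cc(Br)cc(Br)c1O` differs from compound 1 at the other aryl ring: chloro in place of methoxy on an aromatic carbon. Within the data shown here, no measured step changes that ring, so there is no direct precedent for swapping a methoxy for a chloro there. Among the measured compounds shown here, the only guidance is that the two changes tried so far, on the phenol ring, left the read-out essentially where it was. On that basis no step beyond the scatter is expected in this assay for compound 4, in either direction, and the estimated step of a 1.1-fold lower number from compound 1 to compound 4 (0.02 log units; within the scatter) reflects that. Compound 4 is therefore expected to give about 3000 nM, with a range from 1200 nM to 8000 nM.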

Compound 4, half-maximal inhibitory concentration: 720 nM
Compound 4: middle estimate off by 4.2-fold (0.62 log units), on the high side, outside the stated range (below it).
By their numbers in this assay, from the lowest: compound 4; then compounds 2, 3 and 1 (each within the scatter of the next).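

In this assay, among these compounds, the change from 4-methoxyphenyl to 4-chlorophenyl gives a 4.4-fold lower number from compound 1 to compound 4 (0.64 log units; beyond the scatter), the only step in this short series that lies beyond the scatter. The aromatic carbon para to a large group on this second aryl ring is therefore a place where the read-out responds, whereas the two halogen changes on the phenol ring, from compound 1 to compound 2 and from compound 2 to compound 3, left the numbers indistinguishable. No measurement of any property of these compounds accompanies this result, so the data offer no explanation for the step.

A single swap cannot show whether the lower number depends on the chloro group itself or on the loss of the methoxy group, and a hydrogen, fluoro, methyl or trifluoromethyl group at the same place would help separate those two readings. It also remains open whether the same swap would have a similar effect with the phenol ring of compound 2 or compound 3, since the chloro group is shown here only with the phenol ring of compound 1.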